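A few compounds are considered here, and "the series" means these few. Any claim that something is new, unique, unknown or untested is made for them only; others in the source may bear on it.

Measured so far:
Compound 1, `CCNC(=O)c1noc(-c2cc(C(C)C)c(O)cc2O)c1-c1cc(CNCCO)no1`, in a functional assay on HCT-116 cells (Homo sapiens) for inhibition (on this read-out lower numbers stand for stronger inhibition and higher numbers for weaker inhibition), compound 1 gives 111 nM.
Compound 2, `CCNC(=O)c1noc(-c2cc(C(C)C)c(O)cc2O)c1-c1cc(C(=O)OCC)no1`, in this assay compound 2 has "not determined" (no result reported), so no result is reported for it.
Compound 3, `CCNC(=O)c1noc(-c2cc(C(C)C)c(O)cc2O)c1-c1cc(C(N)=O)no1`, in this assay compound 3 gives 79 nM.

Compound 3 has the lowest of the two numbers shown, but its nearest neighbour is compound 1, and the step of a 1.4-fold lower number from compound 1 to compound 3 (0.15 log units; within the scatter) lies within the usual scatter, so the two cannot be ranked. Compound 4, `CCNC(=O)c1noc(-c2cc(C(C)C)c(O)cc2O)c1-c1cnn(C)c1`, shares the core of compound 3 and differs from it only in one place: 1-methyl-1H-pyrazol-4-yl in place of 3-carbamoyl-1,2-oxazol-5-yl on an aromatic carbon. Among the compounds with values here, no measured step bears on this kind of change. The only step shown, from compound 1 to compound 3, swaps a group on the 3-carbamoyl-1,2-oxazol-5-yl ring without moving the number beyond the scatter, so this series has so far tolerated changes at that position. Replacing the whole ring is a larger change than anything measured, and the expectation is therefore uncertain: a step of about a 2.0-fold higher number from compound 3 to compound 4 (0.31 log units; beyond the scatter) is expected, toward a somewhat higher number. Compound 4 is thus estimated at 160 nM, with a range from 50 nM to 500 nM.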

Compound 4, half-maximal inhibitory concentration: 41 nM
Beside the measured number, compound 4's estimate is 3.9-fold (0.59 log units) above it; measured number outside the range, below it.
By their numbers in this assay, from the lowest: compounds 4, 3 and 1 (each within the scatter of the next, the first and the last beyond it).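

In this assay, swapping the whole ring at this position, rather than only a group on it, leaves compound 3 and compound 4 unranked: the result is a 1.9-fold lower number from compound 3 to compound 4 (0.28 log units; within the scatter) and so gives no sign that the hydrogen-bond donor of the 3-carbamoyl-1,2-oxazol-5-yl group is required here. Set against the 3-(((2-hydroxyethyl)amino)methyl)-1,2-oxazol-5-yl group, the 1-methyl-1H-pyrazol-4-yl group gives a 2.7-fold lower number from compound 1 to compound 4 (0.43 log units; beyond the scatter) and thereby provides the first step in this series to pass beyond the scatter, though only modestly. Nothing measured here explains either step.

From the compounds shown here alone, it remains open whether a ring is needed on this carbon at all, or whether a simple amine or a carboxylic acid would serve there instead. Also open, going by these compounds, is how the number responds when a longer chain, such as propyl, replaces the methyl of the 1-methyl-1H-pyrazol-4-yl group.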